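Swapping the carbamate cap on the piperidine of compound 2

The source may report more compounds than this note shows. Statements on the series, on what has been measured and on what is new or still open speak of the compounds shown alone.

Measured compounds:
compound 1, `Cc1nc(S(C)(=O)=O)ccc1O[C@H]1CC[C@H](OC2CCN(C(=O)OC(C)C)CC2)CC1`, 11 nM
compound 2, `CC(C)(C)OC(=O)N1CCC(O[C@H]2CC[C@H](Oc3cnc(S(C)(=O)=O)cn3)CC2)CC1`, 5.9 nM
compound 3, `CC(C)S(=O)(=O)c1cnc(O[C@H]2CC[C@H](OC3CCN(C(=O)OC(C)(C)C)CC3)CC2)cn1`, 18.5 nM

In a functional assay on isolated protein for agonist activity at Glucose-dependent insulinotropic receptor (Homo sapiens), read by HTRF and cAMP accumulation (on this read-out lower numbers stand for an effect already at smaller amounts and higher numbers for an effect only at larger amounts of compound), compound 2 gives 5.9 nM, the lowest of the three numbers. Compound 1 gives 11 nM, within the scatter of compound 2, while compound 3 gives 18.5 nM, which lies beyond it: a 3.1-fold higher number from compound 2 to compound 3 (0.50 log units; beyond the scatter).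

The unmeasured compound 4, `CC(C)c1noc(CN2CCC(O[C@H]3CC[C@H](Oc4cnc(S(C)(=O)=O)cn4)CC3)CC2)n1`, differs from compound 2 in one place: (3-isopropyl-1,2,4-oxadiazol-5-yl)methyl in place of tert-butoxycarbonyl on an amine nitrogen in a ring. Going by the values given here, the only measured step, the one from compound 2 to compound 3, concerns the group on the sulfonyl sulfur, not the amine nitrogen in the ring, so it does not bear on this change. Compounds 1 and 2 differ from each other in two places, so their values give no clean reading of the cap alone. Among the compounds with values here, with no step touching this position, compound 4 is expected to stay close to compound 2, with a 1.0-fold higher number from compound 2 to compound 4 (0.01 log units; within the scatter) judged as a step not beyond the scatter. Compound 4 is therefore estimated at 6 nM in this assay, within a range of 1.5 nM to 25 nM.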

Compound 4, half-maximal effective concentration: 14 nM
Beside the measured number, compound 4's estimate is 2.3-fold (0.37 log units) below it; the range from low to high includes it.
By their numbers in this assay, from the lowest: compounds 2, 1, 4 and 3 (each within the scatter of the next, the first and the last beyond it).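

In this assay, going by these compounds alone, the exchange of the cap gives a 2.4-fold higher number from compound 2 to compound 4 (0.38 log units; beyond the scatter) and so provides the first clean reading at this amine nitrogen: the position responds to its substituent, though only modestly. The tert-butoxycarbonyl can give way to (3-isopropyl-1,2,4-oxadiazol-5-yl)methyl, which brings a five-membered aromatic ring and no double bond outside aromatic rings, and compound 4 still gives 14 nM in the low nanomolar range, so a carbamate is not required on this nitrogen. Nothing at hand accounts for the shift.

As far as these compounds go, it remains open whether an acetyl group, a benzyl group or the free secondary amine on this nitrogen would keep the number near that of compound 2. Also open, from the compounds shown here alone, is whether a cyclopropyl or a trifluoromethyl could replace the isopropyl on the oxadiazole.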